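Pyridin-3-yl in place of 2-methylphenyl on compound 3

The compounds below may be only part of what the source reports. "The series", "measured", "known", "first", "only" and "open" are said of these compounds alone.

Compound 3 `Cc1ccccc1Cc1nc2cc(O[C@H]3CC[C@@H](C(=O)O)CC3)ccc2n1C` gives the highest number of the three measured in an assay on isolated protein for inhibition of Long-chain-fatty-acid--CoA ligase 1 (Mus musculus), read by mass spectrometry, with a stated time of 90 min, in the presence of a further agent that is not named here (on this read-out lower numbers stand for stronger inhibition and higher numbers for weaker inhibition), compound 3 standing at 5400 nM. Within the data shown here, compound 1 `Cc1cccc(Cc2c(C(N)=O)c3cc(O[C@H]4CC[C@@H](C(=O)O)CC4)ccc3n2C)c1` gives 440 nM in this assay and compound 2 `Cc1cccc(Cc2c(C#N)c3cc(O[C@H]4CC[C@@H](C(=O)O)CC4)ccc3n2C)c1` gives 600 nM; the single measured step, a 1.4-fold higher number from compound 1 to compound 2 (0.13 log units; within the scatter), concerns another change on another core. Compound 4 `Cn1c(Cc2cccnc2)nc2cc(O[C@H]3CC[C@@H](C(=O)O)CC3)ccc21` differs from compound 3 by pyridin-3-yl in place of 2-methylphenyl on a saturated chain carbon bound to an aromatic carbon. Among the measured compounds shown here, no measured step bears on this change, so nothing sets a direction for it; with no supporting step, compound 4 is expected to stay near compound 3, and the step of no change at the digits printed from compound 3 to compound 4 (within the scatter) is estimated to lie within the scatter. Compound 4 is therefore expected to give about 5400 nM in this assay, in the range 1500 nM to 18000 nM.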

Compound 4, half-maximal inhibitory concentration: > 200000 nM
Compound 4: a limit, no number (the forecaster's own chance of this, stated with the estimate: 10%); at least 37-fold (1.56 log units) between middle value and limit.
By their numbers in this assay, from the lowest: compounds 1 and 2 (each within the scatter of the next); then compound 3. At a limit, above all of these: compound 4.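

Pyridin-3-yl in place of 2-methylphenyl on a saturated chain carbon bound to an aromatic carbon gives an at least 37-fold higher number from compound 3 to compound 4 (1.56 log units; beyond the scatter) in this assay. Among these compounds, this is the first reading at this position, and it shows that the group here can strongly affect the read-out and that one aromatic ring cannot simply replace another. Compound 4 has a limit of the assay, not a number: the limit of > 200000 nM in this assay, at which 1 of the 4 values shown sits.

The compounds shown do not separate the ring nitrogen from the missing methyl. On these data alone, how an unsubstituted phenyl, an amine on the ring or a longer chain would read here remains open.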